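The source may hold more compounds than are shown below. What is called first, only, known or untested is meant among the compounds shown, and "the series" means these compounds.

Measured so far in a functional assay on SK-MEL-2 cells (Homo sapiens) for inhibition, read by sulforhodamine B assay, with a stated time of 48 h, tested at 10 uM; on this read-out lower numbers stand for less inhibition and higher numbers for more inhibition at the one concentration tested (going by the name of the read-out):
compound 1 `COc1ccc(-c2cn3ccnc3c(-c3ccc4ncn(C5CCCCC5)c4c3)n2)cc1` gives 94.3%
compound 2 `Fc1ccc(-c2cn3ccnc3c(-c3ccc4ncn(C5CCCCC5)c4c3)n2)cc1` gives 9.82%
compound 3 `COc1ccccc1-c1cn2ccnc2c(-c2ccc3ncn(C4CCCCC4)c3c2)n1` gives 12.1%

Compound 3 holds the second highest of the three numbers. It sits close to compound 2, with a number 2.3 percentage points higher from compound 2 to compound 3 (within the scatter), while compound 1 stands far above it, with a number 82.2 percentage points lower from compound 1 to compound 3 (beyond the scatter). The next compound, compound 4 `Fc1ccccc1-c1cn2ccnc2c(-c2ccc3ncn(C4CCCCC4)c3c2)n1`, has not yet been measured. Compared with compound 3 the change is fluoro in place of methoxy on an aromatic carbon.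

For the measured compounds named here, one measured step bears directly on this exchange, the same swap made elsewhere on the ring: a number 84.5 percentage points lower from compound 1 to compound 2 (beyond the scatter), a large fall. The step of a number 2.3 percentage points higher from compound 2 to compound 3 (within the scatter) also matters, since compound 2, which already carries a fluoro group, lies level with compound 3. Because compound 3 starts at 12.1%, there is little room left for another large fall in this assay. The step is therefore expected to be small, a number 4.1 percentage points lower from compound 3 to compound 4 (within the scatter), within the scatter or only just below it. Compound 4 is estimated at 8%, with a range from 0% to 25%.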

Compound 4, a percentage reported as inhibition, at one concentration (the size of the read-out at that concentration, not a potency): 10.5%
Compound 4: middle estimate off by 2.5 percentage points, on the low side, and the stated range covers the measured number.
By their numbers in this assay, from the lowest: compounds 2, 4 and 3 (each within the scatter of the next); then compound 1.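

The exchange of methoxy for fluoro does not give the same step in this assay when it is made on the 2-methoxyphenyl group as when it is made on the 4-methoxyphenyl group: the same change on two cores in this assay, a number 84.5 percentage points lower (beyond the scatter) from compound 1 to compound 2 and a number 1.6 percentage points lower (within the scatter) from compound 3 to compound 4, 82.9 percentage points apart, beyond the scatter of two such steps

On the 2-methoxyphenyl group, ortho to a large group, the exchange has no readable effect, a number 1.6 percentage points lower from compound 3 to compound 4 (within the scatter), and the two fluorophenyl groups also lie level, a number 0.7 percentage points higher from compound 2 to compound 4 (within the scatter). Among these four compounds, only the 4-methoxyphenyl group of compound 1 stands apart, and the 2-fluorophenyl group does not share its number, a number 83.8 percentage points lower from compound 1 to compound 4 (beyond the scatter).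

From the compounds shown here alone, it remains open whether the high number depends on methoxy itself or would also appear with a 4-ethoxyphenyl, 4-hydroxyphenyl or 4-aminophenyl group. Going by these compounds, the effect of a 3-methoxyphenyl group also remains unknown.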